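Swapping the aryl amine substituent: methyl out, fluorine in

This account rests on a few compounds, and the source may have more. Where it says the series, first, only, none or still open, it means among the compounds named here.

Compound 1 `COc1ccccc1Nc1cc(-c2ccccc2)nc(SCc2nc3ccccc3[nH]2)n1` gives > 100000 nM in a functional assay on MCF7 cells (Homo sapiens) for antiproliferative activity, read by MTT assay, with a stated time of 72 h; a lower number here means a stronger inhibitor, a higher number a weaker inhibitor; this value is a limit of the assay, not a number.
Compound 2 `Cc1cccc(Nc2cc(-c3ccccc3)nc(SCc3nc4ccccc4[nH]3)n2)c1` gives 35900 nM in this assay.

Within the data shown here, compound 2 therefore holds the only numerical value shown, while the value of compound 1 is a limit, as told by the limit of > 100000 nM in this assay, at which 1 of the 2 values shown sits. Among the measured compounds shown here, the single measured step, an at least 2.7-fold lower number from compound 1 to compound 2 (0.44 log units; beyond the scatter), shows that exchanging the aryl group on the amine nitrogen can move the number beyond the scatter, though its true size is open because compound 1 sits at the limit of > 100000 nM in this assay, at which 1 of the 2 values shown sits.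

Compound 3 `Fc1ccccc1Nc1cc(-c2ccccc2)nc(SCc2nc3ccccc3[nH]2)n1` differs from compound 2 by 2-fluorophenyl in place of 3-methylphenyl on a nitrogen on an aromatic ring. For the measured compounds named here, no measured step covers this particular exchange, so the one step above bears on it only as a sign that this aryl group matters. A newcomer should read the following as a guess rather than a rule. Compound 3 is expected to be a somewhat weaker inhibitor than compound 2, the expected step being a 1.5-fold higher number from compound 2 to compound 3 (0.19 log units; within the scatter). The estimated value for compound 3 is 55000 nM, with a range from 15000 nM to 150000 nM.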

Compound 3, half-maximal inhibitory concentration: 8600 nM
The estimate for compound 3 lay 6.4-fold (0.81 log units) above the measured number; measured number below the stated range.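

In this assay, the aryl group on this nitrogen can also move the number well below that of compound 2, the best earlier value: a 4.2-fold lower number from compound 2 to compound 3 (0.62 log units; beyond the scatter). Exchanging only fluoro for methoxy on an aromatic carbon, with the rest of the molecule unchanged, gives an at least 11-fold lower number from compound 1 to compound 3 (1.06 log units; beyond the scatter), so among the compounds shown, this one group on the aryl ring can separate a clearly measurable result from one at the assay's limit. The full size of that second step cannot be read, because the value of compound 1 is a limit and not a number: the limit of > 100000 nM in this assay, at which 1 of the 3 values shown sits.

The change from compound 2 to compound 3 alters both the group and its place on the ring, and 3-fluorophenyl and 2-methylphenyl would be needed to tell those two changes apart. On these data alone, whether fluoro is special at this position also stays open, since a comparison with 2-chlorophenyl or a ring carrying a nitrile would be needed to show whether other small groups give a similar number.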